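The source may hold more compounds than are shown below. What is called first, only, known or untested is meant among the compounds shown, and "the series" means these compounds.

In a functional assay on A549 cells (Homo sapiens) for antiproliferative activity, read by MTT assay, with a stated time of 48 h (a higher number here means a weaker inhibitor, a lower number a stronger inhibitor), compound 1 `COc1ccccc1/C=C/C(=O)Nc1ccc2ncnc(Nc3cccc(Br)c3)c2c1` gives 3.55 ug/mL. Compound 2 `O=C(/C=C/c1ccc(Cl)cc1)Nc1ccc2ncnc(Nc3cccc(Cl)c3)c2c1` gives 12.4 ug/mL in this assay, the higher of the two numbers, and its gap to compound 1 lies beyond the usual scatter. Compound 3 `O=C(/C=C/c1ccc(Br)cc1)Nc1ccc2ncnc(Nc3cccc(Cl)c3)c2c1` differs from compound 2 only by bromo in place of chloro on an aromatic carbon. Going by the values given here, no measured pair shows this exchange, so the step of a 1.2-fold lower number from compound 2 to compound 3 (0.09 log units; within the scatter) is expected to be small, with no direction beyond the scatter. Compound 3 is therefore estimated at 10 ug/mL in this assay, within a range from 4 ug/mL to 25 ug/mL.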

Compound 3, half-maximal inhibitory concentration: 1.86 ug/mL
The estimate for compound 3 lay 5.4-fold (0.73 log units) above the measured number; the measured number lies below the stated range.
By their numbers in this assay, from the lowest: compounds 3 and 1 (each within the scatter of the next); then compound 2.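

In this assay, exchanging 4-chlorophenyl for 4-bromophenyl gives a 6.7-fold lower number from compound 2 to compound 3 (0.82 log units; beyond the scatter) and so shows that this single atom, on an aromatic carbon para to a large group, matters beyond the scatter. Going by these compounds alone, the earlier compounds offered no pair differing in one place, so this is the first change that can be read on its own. No measured property bears on this step. On these data alone, whether an amine or a carboxylic acid at this place would give a lower or higher number remains open. So does whether the same exchange at the second chloro of compound 3 would move the number.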